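Dichlorophenyl to 2-bromophenyl on the propoxy side chain

This account rests on a few compounds, and the source may have more. Where it says the series, first, only, none or still open, it means among the compounds named here.

Measured in a functional assay on HCT-116 cells (Homo sapiens) for antiproliferative activity, read by MTT assay, with a stated time of 72 h; on this read-out higher numbers stand for weaker inhibition and lower numbers for stronger inhibition:
compound 1 `NC1=NC2(CCOCC2)N(OCCCOc2cccc(Cl)c2Cl)C(N)=N1`: 5 nM
compound 2 `NC1=NC2(CCOCC2)N(OCCCOc2ccccc2Cl)C(N)=N1`: 70 nM
compound 3 `NC1=NC2(CCOCC2)N(OCCCOc2ccc(Cl)c(Cl)c2)C(N)=N1`: 90 nM

Compound 3 stands at 90 nM. The measured series shows a 1.3-fold higher number from compound 2 to compound 3 (0.11 log units; within the scatter), and also an 18-fold higher number from compound 1 to compound 3 (1.26 log units; beyond the scatter). The next structure is compound 4 `NC1=NC2(CCOCC2)N(OCCCOc2ccccc2Br)C(N)=N1`, with 2-bromophenyl in place of 3,4-dichlorophenyl on an oxygen on a saturated carbon.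

Among the compounds with values here, no bromo compound has been measured, so this step has no direct precedent. The closest measured match is compound 2, which carries 2-chlorophenyl and gives 70 nM. Within the data shown here, the only large drops in the number belong to compound 1, the one compound with 2,3-dichlorophenyl, as seen in a 14-fold higher number from compound 1 to compound 2 (1.15 log units; beyond the scatter). Compound 4 does not carry that group, so a value like that of compound 1 is not expected. Compound 4 is instead expected to sit close to compound 2, and no step beyond the scatter is expected in this assay. The expected step is a 1.5-fold lower number from compound 3 to compound 4 (0.18 log units; within the scatter). Compound 4 is estimated at 60 nM, with an expected range of 20 nM to 180 nM.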

Compound 4, half-maximal inhibitory concentration: 30 nM
Compound 4: middle estimate off by 2.0-fold (0.30 log units), on the high side, within the range that was stated.
By their numbers in this assay, from the lowest: compound 1; then compound 4; then compounds 2 and 3 (each within the scatter of the next).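

In this assay, the halogen itself now matters, since bromo in place of chloro on an aromatic carbon gives a 2.3-fold lower number from compound 2 to compound 4 (0.37 log units; beyond the scatter), a step beyond the scatter on a single change. The earlier compounds shown here left 2-chlorophenyl and 3,4-dichlorophenyl within the scatter of each other, whereas 2-bromophenyl separates from the latter with a 3.0-fold lower number from compound 3 to compound 4 (0.48 log units; beyond the scatter), so compound 4 stands apart from each of the other three compounds, and the phenyl group on this oxygen gives a graded rather than a two-level picture. The 2,3-dichlorophenyl group still gives the lowest number of the series, with a 6.0-fold higher number from compound 1 to compound 4 (0.78 log units; beyond the scatter), and nothing available accounts for any of these steps.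

The compounds shown leave open whether the gain continues with iodo in place of bromo on the aromatic carbon, or whether a dibromophenyl group would match or pass the 2,3-dichlorophenyl group of compound 1. They also leave open how a methoxy group or a nitrile on the phenyl ring, or a longer chain in place of the propoxy side chain, would behave in this assay.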